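Swapping a Hydroxyethyl for an Isopropyl Side Chain

The source may report more compounds than this note shows. Statements on the series, on what has been measured and on what is new or still open speak of the compounds shown alone.

Three compounds share one core and have been tested in a functional assay on the whole organism (Tail, strain ICR) with Mus musculus as the target, in the tail flick test, with a stated time of 60 min, at a dose of 25 umol/kg by the oral route; a lower number here means a weaker effect, a higher number a stronger effect of the compound at the dose given:

Compound 1 `CC(C)[C@H](NC(=O)CN(c1nc(Cl)nc2[nH]cnc12)C1CC1)C(=O)OCc1ccccc1`: 55.5%
Compound 2 `NC(=O)C[C@H](NC(=O)CN(c1nc(Cl)nc2[nH]cnc12)C1CC1)C(=O)O`: 43.1%
Compound 3 `C[C@@H](O)[C@H](NC(=O)CN(c1nc(Cl)nc2[nH]cnc12)C1CC1)C(=O)O`: 30.1%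

Compound 3 stands lowest of the three. Among the compounds with values here, its nearest neighbour is compound 2, and the only single-point step on record, a number 13 percentage points lower from compound 2 to compound 3 (beyond the scatter), is a modest drop beyond the scatter.

Compound 4 `CC(C)[C@H](NC(=O)CN(c1nc(Cl)nc2[nH]cnc12)C1CC1)C(=O)O` has not been measured. It differs from compound 3 in one place: isopropyl in place of 1-hydroxyethyl on a saturated chain carbon bound to an amide-type nitrogen and a carbonyl carbon. Within the data shown here, no measured step covers this exact exchange. Compound 1 also carries an isopropyl group at this position, but it differs from compound 4 in a second place as well; in this assay compound 1 gives 55.5%, which can only hint that an isopropyl group is compatible with a reasonable response.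

Given that the step from compound 2 to compound 3 cost activity and that compound 1 sits highest, compound 4 is expected to recover some ground, estimated at 45% with a range from 25% to 65%, a step of a number 14.9 percentage points higher from compound 3 to compound 4 (beyond the scatter) expected upward.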

Compound 4, a percentage reported as activity, at one dose (the size of the read-out at that dose, not a potency): 38.8%
For compound 4 the middle estimate is 6.2 percentage points above the measured one; the range from low to high includes it.
By their numbers in this assay, from the lowest: compounds 3, 4 and 2 (each within the scatter of the next, the first and the last beyond it); then compound 1.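

Isopropyl in place of 1-hydroxyethyl gives a number 8.7 percentage points higher from compound 3 to compound 4 (within the scatter) in this assay and isopropyl in place of carbamoylmethyl gives a number 4.3 percentage points lower from compound 2 to compound 4 (within the scatter) as well, so at this position isopropyl sits within the scatter of both side chains, even though those two stand apart beyond it. Within the data shown here, at the other place that varies, hydrogen in place of benzyl on an oxygen next to a carbonyl group gives a number 16.7 percentage points lower from compound 1 to compound 4 (beyond the scatter) and is the only new step beyond the scatter, so isopropyl alone does not account for the higher number of compound 1. Nothing measured here bears on why these numbers differ.

Going by these compounds, whether an amine or a longer chain at this position would move the number beyond the scatter remains open. So does whether benzyl on that oxygen would give a similar step alongside the 1-hydroxyethyl or carbamoylmethyl side chains.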